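A few compounds are considered here, and "the series" means these few. Any claim that something is new, unique, unknown or untested is made for them only; others in the source may bear on it.

Measured so far in a functional assay on the whole organism (strain Wistar) for inhibition, with Rattus norvegicus as the target, read by paw edema, with stated times of 3 h and 1 h, at a dose of 6 mg/kg by the oral route; a lower number here means less inhibition, a higher number more inhibition at the dose given (going by the name of the read-out):
compound 1, `COc1ccccc1-c1cc(=O)[nH]n1-c1ccc(C(=O)NNC(=O)CO[N+](=O)[O-])cc1`, gives 57.9%;
compound 2, `O=C(CO[N+](=O)[O-])NNC(=O)c1ccc(-n2[nH]c(=O)cc2-c2ccc(Cl)cc2)cc1`, gives 5.84%;
compound 3, `CCOC(=O)c1c(-c2ccccc2OC)n(-c2ccc(C(=O)NNC(=O)CO[N+](=O)[O-])cc2)[nH]c1=O`, gives 25.1%.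

Compound 3 holds the second highest of the three numbers. It stands below compound 1 by the step of a number 32.8 percentage points lower from compound 1 to compound 3 (beyond the scatter), which came from ethoxycarbonyl in place of hydrogen on an aromatic carbon, and it stands above the number of compound 2.

Compound 4, `CCOC(=O)c1c(-c2ccc(Cl)cc2)n(-c2ccc(C(=O)NNC(=O)CO[N+](=O)[O-])cc2)[nH]c1=O`, is still to be measured. It differs from compound 3 in one place: 4-chlorophenyl in place of 2-methoxyphenyl on an aromatic carbon. The same exchange has been seen once already, between compound 1 and compound 2, on the core that carries hydrogen rather than ethoxycarbonyl, and there it gave a number 52.1 percentage points lower from compound 1 to compound 2 (beyond the scatter). One step is a thin basis, and compound 3 starts much lower than compound 1 did, so a drop of that full size would pass below zero. A large downward step toward the bottom of the scale is therefore expected, of about a number 20.1 percentage points lower from compound 3 to compound 4 (beyond the scatter). For compound 4 a value of 5% is expected in this assay, with a range from 0% to 18%.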

Compound 4, a percentage reported as inhibition, in the whole organism at one dose (the size of the read-out at that dose, not a potency): 6.43%
The estimate for compound 4 lay 1.4 percentage points below the measured number; low and high end bracket the measured number.
By their numbers in this assay, from the lowest: compounds 2 and 4 (each within the scatter of the next); then compound 3; then compound 1.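

In this assay, 4-chlorophenyl in place of 2-methoxyphenyl on the aromatic carbon also lowers the number on the core with ethoxycarbonyl, a number 18.7 percentage points lower from compound 3 to compound 4 (beyond the scatter), so the direction of this change now holds on both cores, while its size does not carry over: the same change on two cores in this assay, a number 52.1 percentage points lower (beyond the scatter) from compound 1 to compound 2 and a number 18.7 percentage points lower (beyond the scatter) from compound 3 to compound 4, 33.4 percentage points apart, beyond the scatter of two such steps

Ethoxycarbonyl in place of hydrogen, a large loss with 2-methoxyphenyl on the ring, gives no readable change with 4-chlorophenyl, a number 0.6 percentage points higher from compound 2 to compound 4 (within the scatter): the same change on two cores in this assay, a number 32.8 percentage points lower (beyond the scatter) from compound 1 to compound 3 and a number 0.6 percentage points higher (within the scatter) from compound 2 to compound 4, 33.4 percentage points apart, beyond the scatter of two such steps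

Across these four compounds the two changes therefore do not simply add, and the effect of each depends on the group carried by the other position; with 4-chlorophenyl present, compound 2 and compound 4 cannot be told apart, and the numbers alone do not show whether they sit at a floor of the read-out.

The series still does not separate the loss of 2-methoxyphenyl from the arrival of 4-chlorophenyl, a question that a plain phenyl group at this position would address. From the compounds shown here alone, it is also open whether the drop seen with ethoxycarbonyl on the core of compound 1 is particular to that ester or would also appear with a carboxylic acid in its place.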